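The source may hold more compounds than are shown below. What is called first, only, known or untested is meant among the compounds shown, and "the series" means these compounds.

Three compounds share one core and differ only in the aryl group attached to it. Compound 1 `O=S(=O)(c1cc(F)cc(F)c1)c1cnc2c(F)cccc2c1-c1cccc(Cl)c1` in an ADME assay on microsomes from liver (Homo sapiens) for metabolic stability, tested at 2.5 uM (on this read-out higher numbers stand for fast clearance and lower numbers for slow clearance), gives 0.64 mL/min, the lowest of the three numbers. Compound 2 `O=S(=O)(c1cc(F)cc(F)c1)c1cnc2c(F)cccc2c1-c1cccc(F)c1` gives 1.18 mL/min, and compound 3 `O=S(=O)(c1cc(F)cc(F)c1)c1cnc2c(F)cccc2c1-c1ccc(Cl)cc1` gives 0.73 mL/min. The measured steps are all small: a 1.8-fold higher number from compound 1 to compound 2 (0.27 log units; within the scatter), a 1.1-fold higher number from compound 1 to compound 3 (0.06 log units; within the scatter) and a 1.6-fold lower number from compound 2 to compound 3 (0.21 log units; within the scatter). None of them separates two compounds beyond the scatter, so the three read as one level rather than as a trend.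

Compound 4 `Cc1ccc(S(=O)(=O)c2cnc3c(F)cccc3c2-c2cccc(Cl)c2)cc1F` is not yet measured. It keeps the chloro-bearing aryl ring of compound 1 and instead changes the ring on the sulfonyl sulfur: 3-fluoro-4-methylphenyl in place of 3,5-difluorophenyl on a sulfonyl sulfur

Within the data shown here, none of the measured steps touches the group on the sulfonyl sulfur; each of them alters the other aryl ring, and each stayed within the scatter. Among the measured compounds shown here, there is therefore no step of the same kind to lean on, and the expectation for compound 4 rests on the narrow spread seen across compounds 1, 2 and 3. On that basis compound 4 is expected to sit close to compound 1, with the step of a 1.4-fold higher number from compound 1 to compound 4 (0.15 log units; within the scatter) expected to remain within the scatter, and the wider range allows for the untested kind of change. The estimated value for compound 4 in this assay is 0.9 mL/min, expected to fall between 0.4 mL/min and 2.2 mL/min.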

Compound 4, intrinsic clearance in a liver preparation (reported as CLH), per the amount of preparation that the assay uses: 3.18 mL/min
Compound 4: the middle estimate sits 3.5-fold (0.55 log units) below what was measured, outside the stated range (above it).
By their numbers in this assay, from the lowest: compounds 1, 3 and 2 (each within the scatter of the next); then compound 4.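

Changing the group on the sulfonyl sulfur gives a 5.0-fold higher number from compound 1 to compound 4 (0.70 log units; beyond the scatter) in this assay and is the only step shown here that lies beyond the scatter, so clearance in this series responds to a change at this place even though the three changes to the other aryl ring stayed within the scatter. The size of the step is notable for such a small swap: 3-fluoro-4-methylphenyl has the same count of heavy atoms as 3,5-difluorophenyl, the same single aromatic ring of carbon, no hydrogen-bond donors or acceptors and no net charge, differing by one more carbon and one fewer fluorine. Nothing among the data presented explains why this swap produces the step.

With only one change at this place, the compounds shown cannot separate the gain of the methyl group from the loss of a fluorine, which a 3-fluorophenyl or a 3,5-dimethylphenyl on the sulfonyl sulfur would help to tell apart. Going by these compounds, it also remains open how clearance would respond to a ring carrying an amine or a carboxylic acid at this place, and whether the step would recur with the aryl rings of compound 2 and compound 3.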